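The source may report more compounds than this note shows. Statements on the series, on what has been measured and on what is new or still open speak of the compounds shown alone.

Measured so far:

Compound 1 `O=C(CCN(Cc1ccc(C(=O)NO)cc1)C(=O)c1ccccc1)NCc1ccccc1` — 12.5 nM
Compound 2 `CN(C)c1ccc(C(=O)N(CCC(=O)NCc2ccccc2)Cc2ccc(C(=O)NO)cc2)cc1` — 14.8 nM

Among the measured compounds shown here, in an assay on Sf9 cells for inhibition of protein deacetylase HDAC6 (Homo sapiens), read by fluorescence, with stated times of 90 min and 30 min (on this read-out lower numbers stand for stronger inhibition and higher numbers for weaker inhibition), compound 2 gives 14.8 nM, the higher of the two numbers measured so far, but its only neighbour lies close: the step of a 1.2-fold higher number from compound 1 to compound 2 (0.07 log units; within the scatter) is within the scatter, so the two compounds cannot be told apart on these data.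

Compound 3 `Cc1ccc(C(=O)N(CCC(=O)NCc2ccccc2)Cc2ccc(C(=O)NO)cc2)cc1` differs from compound 2 in one place: methyl in place of dimethylamino on an aromatic carbon. For the measured compounds named here, the one measured step that bears on this position is the one from compound 1 to compound 2, where placing dimethylamino on that aromatic carbon changed this assay by a 1.2-fold higher number from compound 1 to compound 2 (0.07 log units; within the scatter), which is within the scatter. Swapping dimethylamino for methyl at the same carbon is therefore expected to produce no step beyond the scatter, so for compound 3 the expected step is a 1.1-fold lower number from compound 2 to compound 3 (0.06 log units; within the scatter). Compound 3 is estimated to give 13 nM in this assay, with a likely range from 6 nM to 28 nM.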

Compound 3, half-maximal inhibitory concentration: 16.7 nM
Compound 3: middle estimate off by 1.3-fold (0.11 log units), on the low side, within the range that was stated.
By their numbers in this assay, from the lowest: compounds 1, 2 and 3 (each within the scatter of the next).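

In this assay, this carbon of the aromatic ring has now been compared with three groups: hydrogen, dimethylamino and methyl. Replacing dimethylamino with methyl gives a 1.1-fold higher number from compound 2 to compound 3 (0.05 log units; within the scatter) and placing methyl where hydrogen stood gives a 1.3-fold higher number from compound 1 to compound 3 (0.13 log units; within the scatter) so the second group tried here also leaves the number within the scatter, and the three compounds cannot be told apart. No measurement on hand offers an explanation for this result.

On these data alone, it remains open whether a quite different group on this carbon, such as a carboxylic acid, a primary amine or a longer alkyl chain, would produce a step beyond the scatter. As far as these compounds go, the effect of the same groups on the other carbons of this ring also remains open.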